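The source may report more compounds than this note shows. Statements on the series, on what has been measured and on what is new or still open speak of the compounds shown alone.

Measured in an ADME assay on MDBK cells (Bos taurus) for cytotoxicity, read by MTT assay; a lower number here means that less compound is tolerated, a higher number that more compound is tolerated:

- Compound 1 `OC[C@@H]1[C@@H](O)[C@H](O)[C@@H](O)CN1CC/C=C/CCOc1cc(F)ccc1F`: > 500000 nM (a limit of the assay, not a number)
- Compound 2 `Cc1ccc(C(C)(C)C)c(OCCCCCCN2C[C@H](O)[C@@H](O)[C@H](O)[C@H]2CO)c1`: 85000 nM
- Compound 3 `OC[C@@H]1[C@@H](O)[C@H](O)[C@@H](O)CN1CCCCCCOc1cc(Cl)ccc1Cl`: 320000 nM

Of the two true numbers, the higher belongs to compound 3 at 320000 nM. The nearest is compound 2 at 85000 nM, and that gap lies beyond the usual scatter.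

Compound 4 `CCC1CCCCC1OCCCCCCN1C[C@H](O)[C@@H](O)[C@H](O)[C@H]1CO` has not yet been measured. Compared with compound 3, the 2,5-dichlorophenyl group leaves and a group with one six-membered non-aromatic ring of carbon only enters, on an oxygen on a saturated carbon: a group of 8 heavy atoms (8 carbon; one six-membered non-aromatic ring of carbon only) in place of a group of 8 heavy atoms (6 carbon, 2 chlorine; one six-membered aromatic ring of carbon only), on an oxygen on a saturated carbon.

Among the measured compounds shown here, no two measured compounds differ in just one place, so the size of this step cannot be read from the data and remains a judgement. For the measured compounds named here, the only other true number, from compound 2 at 85000 nM, lies lower, which leans the expectation downwards in this assay. The expected step is modest, close to the scatter: a 2.3-fold lower number from compound 3 to compound 4 (0.36 log units; beyond the scatter). For compound 4 the estimated value is 140000 nM, with an expected range of 45000 nM to 400000 nM.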

Compound 4, half-maximal cytotoxic concentration: 450000 nM
Compound 4: middle estimate off by 3.2-fold (0.51 log units), on the low side; measured number above the stated range.
By their numbers in this assay, from the lowest: compound 2; then compounds 3 and 4 (each within the scatter of the next). At a limit, above all of these: compound 1.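

Replacing the 2,5-dichlorophenyl group with the non-aromatic carbon ring on this oxygen gives a 1.4-fold higher number from compound 3 to compound 4 (0.15 log units; within the scatter) in this assay. Among the compounds shown here, this is the first one-place comparison here, and it shows that at this position, an aromatic ring bearing two chlorines and a non-aromatic ring of carbon only cannot be told apart in this read-out. Compound 1 gives a limit of the assay rather than a number, so the top of the measurable range lies close to these values: the limit of > 500000 nM in this assay, at which 1 of the 4 values shown sits.

On these data alone, whether this tolerance would hold for a group carrying an amine or a carboxylic acid at this position remains open. So does whether a pyridine ring would behave like the two rings compared here.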